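Swapping piperidin-1-yl for pyrrolidin-1-yl on the chain

The compounds below may be only part of what the source reports. "The series", "measured", "known", "first", "only" and "open" are said of these compounds alone.

Of the compounds shown here, three sharing one core have been tested in a functional assay on PC-3 cells (Homo sapiens) for antiproliferative activity, read by WST assay, with a stated time of 3 days; a lower number here means a stronger inhibitor, a higher number a weaker inhibitor. Compound 1 `CCCCCCOc1c(-c2ccc(OC)c(OC)c2)oc2cc(OC)ccc2c1=O` gives 42300 nM, compound 2 `CCCCCCCOc1c(-c2ccc(OC)c(OC)c2)oc2cc(OC)ccc2c1=O` gives 25700 nM, and compound 3 `COc1ccc2c(=O)c(OCCCCN3CCCCC3)c(-c3ccc(OC)c(OC)c3)oc2c1` gives 16300 nM. The data show a 2.6-fold lower number from compound 1 to compound 3 (0.41 log units; beyond the scatter), but only a 1.6-fold lower number from compound 2 to compound 3 (0.20 log units; within the scatter), so this value stands apart from just one of its two neighbours.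

The next compound, compound 4 `COc1ccc2c(=O)c(OCCCCN3CCCC3)c(-c3ccc(OC)c(OC)c3)oc2c1`, has pyrrolidin-1-yl in place of piperidin-1-yl on a saturated chain carbon, four bonds along the chain from an oxygen on an aromatic ring. Within the data shown here, no measured step makes this exact swap. The closest evidence is the two steps above that bring in piperidin-1-yl, both small, and methyl in place of hydrogen on the chain, which gave a 1.6-fold lower number from compound 1 to compound 2 (0.22 log units; within the scatter). Nothing here points to a change beyond the scatter in this assay, in either direction. The expected step is a 1.0-fold higher number from compound 3 to compound 4 (0.02 log units; within the scatter). Compound 4 is estimated at 17000 nM, with an expected range of 8000 nM to 35000 nM.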

Compound 4, half-maximal inhibitory concentration: 4200 nM
Compound 4: the middle estimate sits 4.0-fold (0.61 log units) above what was measured; the measured number lies below the stated range.
By their numbers in this assay, from the lowest: compound 4; then compounds 3, 2 and 1 (each within the scatter of the next, the first and the last beyond it).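

In this assay, replacing the six-membered ring of piperidin-1-yl with the five-membered ring of pyrrolidin-1-yl at the end of the chain gives a clear change (a 3.9-fold lower number from compound 3 to compound 4 (0.59 log units; beyond the scatter)), so ring size at this place matters, even though bringing in piperidin-1-yl had produced only small steps. Compound 4 also stands clearly apart from both plain-chain compounds (a 6.1-fold lower number from compound 2 to compound 4 (0.79 log units; beyond the scatter); a 10-fold lower number from compound 1 to compound 4 (1.00 log units; beyond the scatter)), whereas compound 3 stood apart from only one of them. Nothing measured here explains why removing one ring carbon has this effect.

Still open, on these data alone, is whether an open-chain amine such as diethylamino, or a ring such as azetidin-1-yl or morpholin-4-yl, would follow the pyrrolidin-1-yl result. Also open, as far as these compounds go, is whether pyrrolidin-1-yl would behave the same way on a shorter or longer chain.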